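Swapping a 4-Chlorobenzyl Arm for an Octyl Chain

The source may hold more compounds than are shown below. What is called first, only, known or untested is meant among the compounds shown, and "the series" means these compounds.

Compound 1, `CCOC(=O)C1(Cc2ccccc2)CN(c2ccccc2)Cc2nnn(Cc3cccc(Cl)c3)c21`, in an ADME assay on HEL cells (Homo sapiens) for cytotoxicity, read by microscopy, with a stated time of 3 days (a higher number here means that more compound is tolerated, a lower number that less compound is tolerated), gives only the limit > 100000 nM.
Compound 2, `CCOC(=O)C1(Cc2ccccc2)CN(c2ccccc2)Cc2nnn(Cc3ccc(Cl)cc3)c21`, in this assay likewise gives only the limit > 100000 nM.
Compound 3, `CCOC(=O)C1(Cc2ccccc2)CN(c2ccccc2)Cc2nnn(CCCCCO)c21`, in this assay also gives only the limit > 100000 nM.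

Compound 2 thus stands at the same limit as the other two measured compounds, so no number separates them: the limit of > 100000 nM in this assay, at which 3 of the 3 values shown sit. The new compound 4, `CCCCCCCCn1nnc2c1C(Cc1ccccc1)(C(=O)OCC)CN(c1ccccc1)C2`, differs from compound 2 in one place: heptyl in place of 4-chlorophenyl on a saturated chain carbon bound to an aromatic nitrogen. Within the data shown here, two measured steps touch the same position. The step that the two limits leave unreadable from compound 1 to compound 2 and the step that the two limits leave unreadable from compound 2 to compound 3 both run between limits, so neither can be read in size or direction. With every measured value sitting at the limit, no step beyond the scatter can be expected in this assay from the change to heptyl; the expectation is that compound 4 will also be tolerated up to the limit. Compound 4 is therefore estimated at 150000 nM, with a range from 50000 nM to 500000 nM. The expected step this implies is a step that the limit leaves unreadable from compound 2 to compound 4.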

Compound 4, minimum cytotoxic concentration: >= 20000 nM
Compound 4: a limit, no number; the forecaster's own chance of this, stated with the estimate: 85%; the middle value is on the limit's open side.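

In this assay compound 4 gives only the limit >= 20000 nM. Among these compounds, compounds 1, 2 and 3 also give only limits, so no step from any of them to compound 4 can be read. From the compounds shown here alone, the concentration at which any of these four compounds becomes toxic to the cells stays open, as does whether octyl and 4-chlorobenzyl differ in this respect.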